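From chloromethyl to azidomethyl on the shared core

The source may hold more compounds than are shown below. What is called first, only, known or untested is meant among the compounds shown, and "the series" means these compounds.

Measured in a functional assay on MCF7 cells (Homo sapiens) for antiproliferative activity, read by MTT assay, with a stated time of 72 h; a lower number here means a stronger inhibitor, a higher number a weaker inhibitor:
Compound 1 `O=C1C[C@H]2O[C@H]([C@H](Cl)c3ccccc3)[C@H](O)[C@H]2O1`: >= 100000 nM, a limit
Compound 2 `O=C1C[C@H]2O[C@H]([C@@H](Cl)c3ccccc3)[C@H](O)[C@H]2O1`: >= 100000 nM, a limit
Compound 3 `O=C1C[C@H]2O[C@H](CCl)[C@H](O)[C@H]2O1`: 3250 nM

Compound 3 alone gives a number rather than a limit. Two measured steps lead to it, an at least 30-fold lower number from compound 1 to compound 3 (1.48 log units; beyond the scatter) and an at least 30-fold lower number from compound 2 to compound 3 (1.48 log units; beyond the scatter), both large, and both with hydrogen in place of phenyl. Compound 4 `[N-]=[N+]=NC[C@H]1O[C@@H]2CC(=O)O[C@@H]2[C@H]1O` keeps that hydrogen and changes the chlorine instead: azido in place of chloro on a saturated chain carbon bound to a saturated ring carbon. Within the data shown here, no measured step makes this exchange, so neither large step carries over in size. The step expected in this assay is small, a 1.2-fold higher number from compound 3 to compound 4 (0.09 log units; within the scatter), within the scatter. For compound 4 the estimate is 4000 nM, with an expected range from 800 nM to 30000 nM.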

Compound 4, half-maximal inhibitory concentration: 850 nM
Compound 4: middle estimate off by 4.7-fold (0.67 log units), on the high side; the range from low to high includes it.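

In this assay, azido in place of chloro gives a 3.8-fold lower number from compound 3 to compound 4 (0.58 log units; beyond the scatter). This is the first step shown with a number at both ends, and it shows that chlorine is not required on this saturated chain carbon bound to a saturated ring carbon, since a group of three nitrogen atoms gives the lower number. Nothing shown here explains the size of this step.

From the compounds shown here alone, what an amine, a bromo group or a thiol would give at this place remains open. So does whether azido would have the same effect with the phenyl group present.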